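The compounds below may be only part of what the source reports. "The series", "measured", "known", "first", "only" and "open" are said of these compounds alone.

Measured compounds in a physicochemical assay for lipophilicity; a lower number here means a more polar compound, a higher number a more lipophilic compound:

compound 1, `COc1cc(Br)cc(-c2noc(C3CCN(C)CC3)n2)c1OC`: 3.86
compound 2, `COc1cc(Br)cc(-c2noc(C3CCCN3Cc3ccccc3)n2)c1OC`: 5.52

Compound 1 stands lowest of the two numbers. Its nearest neighbour is compound 2, and the two values show compound 2 sitting well above compound 1, beyond the usual scatter. Within the data shown here, no step between measured compounds that differ in one place is available, so nothing has yet been seen for a single change on the shared core in this assay.

Compound 3, `COc1cc(Br)cc(-c2noc(C3CCCN(C)C3)n2)c1OC`, is not yet measured. It differs from compound 1 as follows: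

1-methylpiperidin-3-yl in place of 1-methylpiperidin-4-yl on an aromatic carbon

The two compounds have the same atoms, joined differently, with no change in donors, acceptors or charge. From compound 1 to compound 3 the step in this assay is expected to be small, with no direction beyond the scatter, as a number 0.09 log units higher from compound 1 to compound 3 (within the scatter). For compound 3 the estimated value in this assay is 3.95, with a range from 3.6 to 4.3.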

Compound 3, partition coefficient: 4.08
For compound 3 the middle estimate is 0.13 log units below the measured one; low and high end bracket the measured number.
By their numbers in this assay, from the lowest: compounds 1 and 3 (each within the scatter of the next); then compound 2.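

In this assay, among these compounds, 1-methylpiperidin-3-yl in place of 1-methylpiperidin-4-yl on an aromatic carbon gives the first single-place comparison, a number 0.22 log units higher from compound 1 to compound 3 (within the scatter). At this position on the shared core, moving the attachment point within the piperidine therefore does not separate the two compounds in this read-out. Nothing measured here speaks to the reason for this result.

This single step says only how the two isomers compare and gives no guide to a change that alters the atoms of the group at this position. Still open, as far as these compounds go, is how the read-out responds when the methyl on the piperidine nitrogen gives way to a benzyl group, or when the piperidine gives way to a carboxylic acid or a longer chain.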